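The source may hold more compounds than are shown below. What is called first, only, known or untested is meant among the compounds shown, and "the series" means these compounds.

In an ADME assay on S9 fraction from liver (Rattus norvegicus) for metabolic stability, read by LC-MS, using NADPH, with a stated time of 30 min (a higher number here means that more of the compound is left, a lower number that less of the compound is left), compound 1 (`CCCCCCCCc1ccc(OCC(=O)Cn2ncnn2)cc1`) gives < 5%, which is a limit of the assay and not a number. This is the limit of < 5% in this assay, at which 1 of the 3 values shown sits.

Compound 4 (`CCCCCCCCc1ccc(OCC(=O)Cn2nnnc2C)cc1`) differs from compound 1 in one group: 5-methyl-1H-tetrazol-1-yl in place of 2H-tetrazol-2-yl on a saturated chain carbon bound to a carbonyl carbon. Two measured steps start from compound 1 and change the same group. Compound 2 (`CCCCCCCCc1ccc(OCC(=O)Cn2nnc(-c3ccc(Cl)cc3)n2)cc1`) gives 74%, and compound 3 (`CCCCCCCCc1ccc(OCC(=O)Cn2nnc(-c3cccc(C(=O)OC)c3)n2)cc1`) gives 19%. These are a number at least 69 percentage points higher from compound 1 to compound 2 (beyond the scatter) and a number at least 14 percentage points higher from compound 1 to compound 3 (beyond the scatter), and the two products are themselves far apart: a number 55 percentage points lower from compound 2 to compound 3 (beyond the scatter).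

Both steps add a substituted phenyl, whereas compound 4 gains none, so they bear on it only loosely. A small upward step is therefore expected in this assay, and possibly none beyond the scatter, rather than a repeat of a number at least 69 percentage points higher from compound 1 to compound 2 (beyond the scatter). The expected change is a number at least 3 percentage points higher from compound 1 to compound 4 (that floor lies within the scatter). For compound 4 the estimated value is 8%, with an expected range from 2% to 25%.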

Compound 4, percent of the compound remaining: 32%
For compound 4 the middle estimate is 24 percentage points below the measured one; measured number outside the range, above it.
By their numbers in this assay, from the lowest: compound 3; then compound 4; then compound 2. At a limit, below all of these: compound 1.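

In this assay, among these compounds, the earlier steps all added a substituted phenyl, whereas this one brings in only 5-methyl-1H-tetrazol-1-yl in place of 2H-tetrazol-2-yl, and it still gives a number at least 27 percentage points higher from compound 1 to compound 4 (beyond the scatter). A phenyl group on the tetrazole is therefore not required for a step beyond the scatter at this position on the saturated chain carbon bound to a carbonyl carbon. The true size of the step remains unknown, as the value of compound 1 is a limit of the assay and not a number: the limit of < 5% in this assay, at which 1 of the 4 values shown sits.

The compounds shown leave open whether the methyl group or the change in how the tetrazole is attached accounts for the step, since compound 4 differs from compound 1 in both. A 5-methyl-2H-tetrazol-2-yl group or an unsubstituted 1H-tetrazol-1-yl group at the same place would separate the two.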